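This account rests on a few compounds, and the source may have more. Where it says the series, first, only, none or still open, it means among the compounds named here.

Compound 1 `COc1ccc(/C=C\c2cc(OC)c(OC)c(OC)c2)cc1OCc1ccc(CN2CC[C@@H](C(=O)O)C2)cc1` gives 2300 nM in a functional assay on HepG2 cells (Homo sapiens) for antiproliferative activity, read by CCK-8 assay, with a stated time of 48 h; on this read-out lower numbers stand for stronger inhibition and higher numbers for weaker inhibition. Compound 2 `COc1ccc(/C=C\c2cc(OC)c(OC)c(OC)c2)cc1OCc1ccc(CN[C@H](C(=O)O)[C@@H](C)O)cc1` reaches only a limit in this assay, > 10000 nM. Compound 2 thus stands at the limit of > 10000 nM in this assay, at which 1 of the 2 values shown sits, with no number of its own. Going by the values given here, the single measured step, an at least 4.3-fold higher number from compound 1 to compound 2 (0.63 log units; beyond the scatter), concerns a different change and does not bear on the move to compound 3 `COc1ccc(/C=C\c2cc(OC)c(OC)c(OC)c2)cc1OCc1ccc(CNC(C)(C)C(=O)O)cc1`, which carries 1-carboxy-1-methylethyl in place of 1-carboxy-2-hydroxypropyl on an amine nitrogen. Among the compounds with values here, with no step to lean on, compound 3 is expected to stay near the limit, an expected step of a number no higher from compound 2 to compound 3 (the limit leaves the size open). The estimate for compound 3 is 10000 nM, between 3000 nM and 30000 nM.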

Compound 3, half-maximal inhibitory concentration: 6500 nM
Compound 3: middle estimate off by 1.5-fold (0.19 log units), on the high side; the measured number falls inside the stated range.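

In this assay compound 2 has only a limit and no number of its own: the limit of > 10000 nM in this assay, at which 1 of the 3 values shown sits. Swapping 1-carboxy-2-hydroxypropyl for 1-carboxy-1-methylethyl on the amine nitrogen yields a measurable value, but the step is only an at least 1.5-fold lower number from compound 2 to compound 3 (0.18 log units; that floor lies within the scatter), so its true size cannot be read. The (1-carboxy-1-methylethyl)amino group still falls short of 3-carboxypyrrolidin-1-yl, with a 2.8-fold higher number from compound 1 to compound 3 (0.45 log units; beyond the scatter).

Still open, going by these compounds, is how a methyl ester would fare in place of the carboxylic acid. Also open, on these data alone, is whether a longer chain bearing the carboxylic acid would restore or lose activity.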